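Chain lengthening from compound 1 to compound 3

The source may hold more compounds than are shown below. What is called first, only, known or untested is meant among the compounds shown, and "the series" means these compounds.

compound 1 `CCCCCC(=O)Nc1nc(N)nc2c1ncn2[C@H]1CO[C@@H](CO)O1` gives > 100000 nM (a limit)
compound 2 `CCCCCCCCCCCC(=O)Nc1nc(N)nc2c1ncn2[C@H]1CO[C@@H](CO)O1` gives > 100000 nM (a limit)
compound 3 `CCCCCCCCCCCCCCCC(=O)Nc1nc(N)nc2c1ncn2[C@H]1CO[C@@H](CO)O1` not yet measured

In a functional assay on HepG2 cells (Homo sapiens) for cytotoxicity (on this read-out lower numbers stand for higher toxicity in this test and higher numbers for lower toxicity in this test), compound 1 gives > 100000 nM as a limit, not a number. Compound 3 carries decyl in place of hydrogen on a saturated chain carbon, five bonds along the chain from a carbonyl carbon relative to compound 1. Within the data shown here, the one measured step that bears on this, a step that the two limits leave unreadable from compound 1 to compound 2, places hexyl at the same carbon, and its size cannot be read (the limit of > 100000 nM in this assay, at which 2 of the 2 values shown sit). For a number no higher from compound 1 to compound 3 (the limit leaves the size open) no change beyond the scatter is expected, and another limit is the likeliest report. In this assay compound 3 is estimated at 100000 nM with an expected range of 50000 nM to 200000 nM for a measured number.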

Compound 3, half-maximal cytotoxic concentration: > 100000 nM
Compound 3 gave a limit, no number (the forecaster's own chance of this, stated with the estimate: 80%); the middle value lies on the limit itself.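

No step among compound 1, compound 2 and compound 3 can be read in this assay, as each result is a limit, not a number: the limit of > 100000 nM in this assay, at which 3 of the 3 values shown sit.

The compounds shown leave open whether chain length alters cytotoxicity at all.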